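A second fluoro on compound 2

The source may hold more compounds than are shown below. What is called first, only, known or untested is meant among the compounds shown, and "the series" means these compounds.

Compound 1 `O=C1C=CC(=O)c2cnccc21`: 374 nM
Compound 2 `O=C1C(Nc2cccc(F)c2)=CC(=O)c2ncccc21`: 805 nM
Compound 3 `O=C1C(Nc2ccc(F)c(F)c2)=CC(=O)c2ncccc21`: 251 nM

All three values come from a functional assay (aorta) for inhibition, with Rattus norvegicus as the target; on this read-out lower numbers stand for an effect already at smaller amounts and higher numbers for an effect only at larger amounts of compound. Compound 2 stands highest of the three, so it needs the largest amount for its effect. Compound 4 `O=C1C(Nc2cc(F)cc(F)c2)=CC(=O)c2ncccc21` is compound 2 with one change: fluoro in place of hydrogen on an aromatic carbon. Going by the values given here, only one measured step is of the same kind, fluoro in place of hydrogen on an aromatic carbon: a 3.2-fold lower number from compound 2 to compound 3 (0.51 log units; beyond the scatter). A single modest step is thin evidence, and its end point is not the same structure as compound 4. A lower number of similar or somewhat smaller size is therefore expected in this assay. The expected change is a 2.4-fold lower number from compound 2 to compound 4 (0.39 log units; beyond the scatter). For compound 4 the estimated value is 330 nM, with an expected range from 120 nM to 800 nM.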

Compound 4, half-maximal effective concentration: 449 nM
Compound 4: the middle estimate sits 1.4-fold (0.13 log units) below what was measured, within the range that was stated.
By their numbers in this assay, from the lowest: compounds 3, 1, 4 and 2 (each within the scatter of the next, the first and the last beyond it).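

Placed on this carbon, meta to a fluoro group, the added fluoro gives a 1.8-fold lower number from compound 2 to compound 4 (0.25 log units; within the scatter). The same kind of change on another carbon of the ring gives a 3.2-fold lower number from compound 2 to compound 3 (0.51 log units; beyond the scatter), so adding a second fluoro does not by itself give a step beyond the scatter. Nothing available here gives a measured reason for this outcome. From the compounds shown here alone, whether a chloro or methoxy group on this same carbon would give a step beyond the scatter stays open. So does the effect of an amine there.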